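The source may report more compounds than this note shows. Statements on the series, on what has been measured and on what is new or still open speak of the compounds shown alone.

Measured so far in a physicochemical assay for solubility, in phosphate buffer, with a stated time of 24 h, at pH 7.4, tested at 100 uM; a lower number here means a less soluble compound, a higher number a more soluble compound:
- compound 1 `O=C(NCc1ccc(S(=O)(=O)N2CCC[C@@H](O)C2)cc1)N1Cc2ccncc2C1`: 216000 nM
- compound 2 `CN1CCN(S(=O)(=O)c2ccc(CNC(=O)N3Cc4ccncc4C3)cc2)CC1`: 160000 nM

Within the data shown here, compound 2 stands within the scatter of the only other measured compound, so the two cannot be told apart in this assay.

The next compound is compound 3 `O=C(NCc1ccc(S(=O)(=O)N2CCC(N3CCCC3)CC2)cc1)N1Cc2ccncc2C1`, which has 4-(pyrrolidin-1-yl)piperidin-1-yl in place of 4-methylpiperazin-1-yl on a sulfonyl sulfur.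

Among the measured compounds shown here, only one measured step bears on this change. It falls at the same place, where 4-methylpiperazin-1-yl replaced 3-hydroxypiperidin-1-yl, and it gave a 1.4-fold lower number from compound 1 to compound 2 (0.13 log units; within the scatter). For the measured compounds named here, no measured compound carries 4-(pyrrolidin-1-yl)piperidin-1-yl, so the data give no direct reading of that group, and a single step cannot establish a trend.

Going by the values given here, with that one exchange on the sulfonyl sulfur as the only guide, no change beyond the scatter is expected, and no direction is favoured. The expected step is a 1.1-fold lower number from compound 2 to compound 3 (0.06 log units; within the scatter).

For compound 3 the estimated value is 140000 nM, with an expected range of 80000 nM to 230000 nM.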

Compound 3, solubility: 6200 nM
The estimate for compound 3 lay 23-fold (1.35 log units) above the measured number; the whole stated range lies above it.
By their numbers in this assay, from the lowest: compound 3; then compounds 2 and 1 (each within the scatter of the next).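

In this assay, among these compounds, the group on the sulfonyl sulfur now makes a clear difference: 4-(pyrrolidin-1-yl)piperidin-1-yl in place of 4-methylpiperazin-1-yl gives a 26-fold lower number from compound 2 to compound 3 (1.41 log units; beyond the scatter), whereas the only earlier exchange at this place stayed within the scatter. The same entering group in place of 3-hydroxypiperidin-1-yl gives a 35-fold lower number from compound 1 to compound 3 (1.54 log units; beyond the scatter), so the step is large from either starting compound, and compound 3 stands apart from compounds 1 and 2, which cannot be told apart. No measurement alongside these numbers bears on what lies behind this step.

Still open, from the compounds shown here alone, is which part of the entering group carries the step, the pyrrolidin-1-yl ring or the piperidin-1-yl ring that holds it, since the two arrive together in compound 3. Going by these compounds, a 4-(dimethylamino)piperidin-1-yl group or a plain morpholin-4-yl group on the sulfonyl sulfur would help separate these parts, and whether the step holds on any other core also remains unknown from these three compounds.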